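Fluorine addition on two pyrazoline cores: the next compound

A few compounds are considered here, and "the series" means these few. Any claim that something is new, unique, unknown or untested is made for them only; others in the source may bear on it.

Measured so far:
Compound 1, `CC(C)(C)C1=NN(c2cccc(Cl)c2)C(c2ccc(O)cc2)C1`, 5200 nM
Compound 2, `CC(C)(C)C1=NN(c2ccc(F)c(Cl)c2)C(c2ccc(O)cc2)C1`, 900 nM
Compound 3, `Oc1ccc(C2CC(c3ccccc3O)=NN2c2cccc(Cl)c2)cc1F`, 2900 nM

The three compounds were tested in an assay on isolated protein for inhibition of protein kinase C zeta type (Homo sapiens), with a stated time of 4 min; a lower number here means a stronger inhibitor, a higher number a weaker inhibitor. Compound 1 and compound 2 share one core; compound 3 carries a different core, and the difference between the two cores is not broken down here. Compound 3 stands closest to compound 1, within the scatter, and further from compound 2, beyond it.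

Between compound 1 and compound 2 the change is fluoro in place of hydrogen on an aromatic carbon, and it made a 5.8-fold lower number from compound 1 to compound 2 (0.76 log units; beyond the scatter). Compound 4, `Oc1ccccc1C1=NN(c2cccc(Cl)c2)C(c2cc(F)c(O)c(F)c2)C1`, is not yet measured; it differs from compound 3 by fluoro in place of hydrogen on an aromatic carbon. This is the same kind of change, but the place is not the same: in compound 2 the fluoro sits ortho to a chloro group and para to a large group, while in compound 4 it sits ortho to a hydroxy group, meta to a fluoro group and meta to a large group.

Because the earlier step was a 5.8-fold lower number from compound 1 to compound 2 (0.76 log units; beyond the scatter) on another core and at another place, compound 4 is expected to show a smaller step, a 1.9-fold lower number from compound 3 to compound 4 (0.29 log units; within the scatter). Compound 4 is estimated at 1500 nM, likely between 600 nM and 4000 nM.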

Compound 4, half-maximal inhibitory concentration: 11100 nM
For compound 4 the middle estimate is 7.4-fold (0.87 log units) below the measured one, and the stated range ends below it.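

In this assay, going from 3-fluoro-4-hydroxyphenyl to 3,5-difluoro-4-hydroxyphenyl gave a 3.8-fold higher number from compound 3 to compound 4 (0.58 log units; beyond the scatter). Among these compounds, the same kind of change therefore moved the number in opposite directions in the two pairs, and the two steps differ: the same change on two cores in this assay, a 5.8-fold lower number (0.76 log units; beyond the scatter) from compound 1 to compound 2 and a 3.8-fold higher number (0.58 log units; beyond the scatter) from compound 3 to compound 4, 22-fold (1.34 log units) apart, beyond the scatter of two such steps This does not show that the core alone sets the outcome: the place of the fluoro changes along with the core, there is only one pair for each core, and these compounds cannot separate the two.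

The compounds shown leave open whether a fluoro placed as in compound 2 would also lower the number on the core of compound 3, and whether one placed as in compound 4 would raise it on the core of compound 1. Also open, from the compounds shown here alone, is how a methoxy group or an amine would read in place of the added fluoro of compound 4.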